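Sulfonylanilide series: ring change at the sulfonyl sulfur

The compounds below may be only part of what the source reports. "The series", "measured", "known", "first", "only" and "open" are said of these compounds alone.

Measured compounds:
compound 1 `CC(O)(C(=O)Nc1ccc(S(=O)(=O)c2ccccc2)c(O)c1)C(F)(F)F` 430 nM
compound 2 `COc1ccccc1S(=O)(=O)c1ccc(NC(=O)C(C)(O)C(F)(F)F)cc1` 1600 nM
compound 3 `CC(O)(C(=O)Nc1ccc(S(=O)(=O)c2ccccc2)c(C(=O)O)c1)C(F)(F)F`; a limit, see below
compound 4 `CC(O)(C(=O)Nc1ccc(S(=O)(=O)c2cccnc2)cc1)C(F)(F)F`; not yet measured

In a functional assay (Cavia porcellus) with sulfonylurea receptors; K-ATP channels (Homo sapiens) as the target (a higher number here means a weaker inhibitor, a lower number a stronger inhibitor), compound 1 gives 430 nM and compound 2 gives 1600 nM. For compound 3 the assay reports only > 30000 nM, which is a limit and not a number. Within the data shown here, the one step measured within this set, an at least 69-fold higher number from compound 1 to compound 3 (1.84 log units; beyond the scatter), rests on that limit (the limit of > 30000 nM in this assay, at which 1 of the 3 values shown sits). Of the two numbers shown, compound 2 holds the higher one; compound 1 is its nearest neighbour and sits beyond the scatter below it.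

The step to compound 4 is pyridin-3-yl in place of 2-methoxyphenyl on a sulfonyl sulfur. Among the measured compounds shown here, no measured step touches this position: the only step on record changes the group on the anilide ring, not the ring on the sulfonyl sulfur, so it gives no direction for the present change. With compound 2 as the only measured point carrying a substituted sulfonyl aryl ring, the expectation is no step beyond the scatter, a 1.1-fold lower number from compound 2 to compound 4 (0.03 log units; within the scatter), in this assay. Compound 4 is therefore estimated at 1500 nM, within 400 nM to 6000 nM, with the range kept wide for want of a bearing step.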

Compound 4, half-maximal inhibitory concentration: 3500 nM
For compound 4 the middle estimate is 2.3-fold (0.37 log units) below the measured one; the measured number falls inside the stated range.
By their numbers in this assay, from the lowest: compound 1; then compound 2; then compound 4. At a limit, above all of these: compound 3.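

In this assay, among these compounds, the ring on the sulfonyl sulfur turns out not to be a neutral site: a 2.2-fold higher number from compound 2 to compound 4 (0.34 log units; beyond the scatter) is the first measured step at this position, and it goes towards a weaker inhibitor. Among the compounds shown here, the change is modest, yet it lies beyond the scatter, and the only earlier step, made at another place on the core, gave no sign of this. No measurement shown bears on the cause of this step, and the one limit on record concerns a different compound and a different change.

Pyridin-3-yl in place of 2-methoxyphenyl removes the methoxy group and brings a ring nitrogen in a single change, so the share of each in the step stays open. A plain phenyl ring on the sulfonyl sulfur of the same core, or a phenyl ring carrying an amine, would be needed to tell these two parts apart and to show whether any substituent on this ring matters.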